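The compounds below may be only part of what the source reports. "The series", "measured", "known", "first", "only" and "open" are said of these compounds alone.

Three measured compounds form the background to this step. Compound 1 `COc1ccc(C(=O)/C(=C/c2ccc([N+](=O)[O-])cc2)CCOC(C)=O)cc1` was tested in a functional assay on MCF7 cells (Homo sapiens) for inhibition, read by XTT assay, with a stated time of 48 h; on this read-out higher numbers stand for weaker inhibition and lower numbers for stronger inhibition; in this assay compound 1 gives only a limit, > 100000 nM. Compound 2 `COc1ccc(C(=O)/C(=C/c2ccc(Cl)cc2Cl)CN(C)C(=O)c2ccccc2)cc1` is likewise recorded only as a limit in this assay, > 100000 nM. Compound 3 `C=C(C/C(=C\c1ccc(OC(=O)c2ccccc2)cc1)C(=O)c1ccc(OC)cc1)C(=O)c1ccc(OC)cc1`, the starting point of the step followed here, also reaches no number in this assay and stands at the limit, > 100000 nM. Within the data shown here, all three values sit at the same place, namely (the limit of > 100000 nM in this assay, at which 3 of the 3 values shown sit); no measured compound gives a number against which compound 3 could be ordered.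

Compound 4 `C=C(C/C(=C\c1ccccc1)C(=O)c1ccc(OC)cc1)C(=O)c1ccc(OC)cc1` has not yet been measured in this assay. It differs from compound 3 by hydrogen in place of benzoyloxy on an aromatic carbon. Among the measured compounds shown here, no measured pair shows what such a change does, and every value shown is a limit. With no number at hand, the expectation for compound 4 is that the step of a number no higher from compound 3 to compound 4 (the limit leaves the size open) is nothing beyond the scatter, another limit being the most likely outcome. Compound 4 is therefore estimated at 100000 nM in this assay, within the range 20000 nM to 300000 nM.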

Compound 4, half-maximal inhibitory concentration: 27100 nM
Compound 4: the middle estimate sits 3.7-fold (0.57 log units) above what was measured; the measured number falls inside the stated range.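

In this assay, among these compounds, putting hydrogen in place of benzoyloxy on this aromatic carbon, para to a large group, gives an at least 3.6-fold lower number from compound 3 to compound 4 (0.56 log units; beyond the scatter), the first step that can be read at all. On these data alone, because compound 3 stands at a limit, the step has only a lower bound, and its true size remains unknown. Compound 4 is the only compound shown that reaches a number, while the others remain at the limit: the limit of > 100000 nM in this assay, at which 3 of the 4 values shown sit.

The compounds shown leave open whether a hydroxyl group, a fluorine atom or an amine on this carbon would give a number close to that of compound 4 or return to the limit. Compound 1 and compound 2 differ from compound 4 in more than one place, so they cannot show whether the same change would act on other cores.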